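A few compounds are considered here, and "the series" means these few. Any claim that something is new, unique, unknown or untested is made for them only; others in the source may bear on it.

In a functional assay on KM12 cells (Homo sapiens) for cytotoxicity, read by sulforhodamine B assay, with a stated time of 48 h (a lower number here means a stronger inhibitor of growth, a higher number a weaker inhibitor of growth), three compounds have been measured. Compound 1 `Nc1nc(Cl)c2ncn(Cc3ccccc3CCl)c2n1` gives 38900 nM, compound 2 `ClCc1ccccc1Cn1cnc2nc(Cl)nc(Cl)c21` gives 25700 nM, and compound 3 `ClCc1ccc(Cn2cnc3c(Cl)nc(Cl)nc32)cc1` gives 3240 nM. Compound 2 thus holds the second highest of the three numbers: its value sits within the scatter of that of compound 1, while compound 3 lies clearly lower, beyond the scatter. Compound 4 `ClCc1ccccc1Cn1cnc2ncnc(Cl)c21`, not yet measured, differs from compound 2 by hydrogen in place of chloro on an aromatic carbon. For the measured compounds named here, no measured pair shows this change, so nothing is known of its effect here. Removing chloro in favour of hydrogen is expected to raise the number only modestly, with the step of a 1.4-fold higher number from compound 2 to compound 4 (0.13 log units; within the scatter) expected to remain near the scatter. Compound 4 is therefore estimated at 35000 nM, within a range from 12000 nM to 100000 nM.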

Compound 4, concentration for total growth inhibition: 11200 nM
Compound 4: the middle estimate sits 3.1-fold (0.49 log units) above what was measured; the whole stated range lies above it.
By their numbers in this assay, from the lowest: compound 3; then compound 4; then compounds 2 and 1 (each within the scatter of the next).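

In this assay, replacing chloro with hydrogen on the aromatic carbon between two ring nitrogen atoms gives a 2.3-fold lower number from compound 2 to compound 4 (0.36 log units; beyond the scatter), a modest step beyond the scatter. In this single pair, the chloro at this place is therefore not required for growth inhibition, and its removal goes with a lower number. Nothing available explains the direction of this step. The compounds shown leave open how a methoxy group or a fluoro group would fare at this place. They also leave open whether the same change would lower the number from compound 3.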